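The source may hold more compounds than are shown below. What is called first, only, known or untested is meant among the compounds shown, and "the series" means these compounds.

Measured compounds:
compound 1 `Cc1ccc(C(=O)OC2(C(=O)Nc3ccc([N+](=O)[O-])cc3)CCCCC2)cc1` — 61.2 nM
compound 2 `O=C(/C=C/c1ccccc1)OC1(C(=O)Nc2ccc([N+](=O)[O-])cc2)CCCCC1` — 52.9 nM

In a functional assay on HepG2 cells (Homo sapiens) for inhibition, read by MTT assay, with a stated time of 72 h (a lower number here means a stronger inhibitor, a higher number a weaker inhibitor), compound 2 holds the lower of the two numbers, though the step between the two a 1.2-fold lower number from compound 1 to compound 2 (0.06 log units; within the scatter) lies within the scatter, so neither can be ranked. Compound 3 `O=C(OC1(C(=O)Nc2ccc([N+](=O)[O-])cc2)CCCCC1)c1ccccc1` has phenyl in place of 2-phenylethenyl on a carbonyl carbon. Going by the values given here, the only measured step at this carbonyl carbon is the one from compound 1 to compound 2 a 1.2-fold lower number from compound 1 to compound 2 (0.06 log units; within the scatter), which swapped one ester aryl group for another with no change beyond the scatter. A step of that kind is therefore expected here as well, none beyond the scatter a 1.1-fold higher number from compound 2 to compound 3 (0.05 log units; within the scatter). Compound 3 is estimated at 60 nM, between 30 nM and 120 nM.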

Compound 3, half-maximal inhibitory concentration: 734 nM
Beside the measured number, compound 3's estimate is 12-fold (1.09 log units) below it; measured number above the stated range.
By their numbers in this assay, from the lowest: compounds 2 and 1 (each within the scatter of the next); then compound 3.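

In this assay this carbonyl carbon turns out not to tolerate every aryl group: removing the double bond of the 2-phenylethenyl group gives a 14-fold higher number from compound 2 to compound 3 (1.14 log units; beyond the scatter), and removing the methyl of the 4-methylphenyl group gives a 12-fold higher number from compound 1 to compound 3 (1.08 log units; beyond the scatter). The earlier pair had suggested that the group here made no difference, yet only phenyl stands apart, while the 4-methylphenyl and 2-phenylethenyl groups remain within the scatter of each other. No measurement shown here accounts for this gap. On these data alone, it remains open whether a methoxy group or a chlorine in place of that methyl, or a 2-phenylethyl group in place of the 2-phenylethenyl group, would keep the lower numbers.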